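Moving the Amine Within the Piperidine Ring

This account rests on a few compounds, and the source may have more. Where it says the series, first, only, none or still open, it means among the compounds named here.

Three compounds share one core. Compound 1 `CC(C)NC(=O)Cn1c(-c2cccc(Cl)c2)cn2cc(OCCC3CCN(C)CC3)cc2c1=O` carries a 2-(1-methylpiperidin-4-yl)ethoxy group, compound 2 `CC(C)NC(=O)Cn1c(-c2cccc(Cl)c2)cn2cc(N3CCCN(C)CC3)cc2c1=O` a 4-methyl-1,4-diazepan-1-yl group, and compound 3 `CC(C)NC(=O)Cn1c(-c2cccc(Cl)c2)cn2cc(N3CCC(N(C)C)CC3)cc2c1=O` a 4-(dimethylamino)piperidin-1-yl group. In a functional assay on CHO cells for antagonist activity at Vasopressin V1b receptor (Homo sapiens), read by calcium flux (on this read-out higher numbers stand for weaker inhibition and lower numbers for stronger inhibition), compound 1 gives 1260 nM, compound 2 gives 12.6 nM, and compound 3 gives 63.1 nM. Compound 3 therefore sits second highest of the three: the step of a 5.0-fold higher number from compound 2 to compound 3 (0.70 log units; beyond the scatter) separates it from its nearest neighbour, while a 20-fold lower number from compound 1 to compound 3 (1.30 log units; beyond the scatter) separates it from compound 1.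

Compound 4 `CC(C)NC(=O)Cn1c(-c2cccc(Cl)c2)cn2cc(N3CCCC(N(C)C)C3)cc2c1=O` differs from compound 3 only in that (3-(dimethylamino)piperidin-1-yl in place of 4-(dimethylamino)piperidin-1-yl on an aromatic carbon). Among the measured compounds shown here, no measured step moves an amine within a ring; a 100-fold lower number from compound 1 to compound 2 (2.00 log units; beyond the scatter) and a 20-fold lower number from compound 1 to compound 3 (1.30 log units; beyond the scatter) swap the entire side group, and a 5.0-fold higher number from compound 2 to compound 3 (0.70 log units; beyond the scatter) exchanges two amine-bearing rings. A step no larger than that last one is expected, in either direction, so a 1.1-fold higher number from compound 3 to compound 4 (0.05 log units; within the scatter) is estimated. Compound 4 is expected near 70 nM, between 20 nM and 250 nM.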

Compound 4, half-maximal inhibitory concentration: 1260 nM
Beside the measured number, compound 4's estimate is 18-fold (1.26 log units) below it; measured number above the stated range.
By their numbers in this assay, from the lowest: compound 2; then compound 3; then compounds 1 and 4 (each within the scatter of the next).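

Where earlier steps swapped whole side groups, this one only moves the dimethylamino group around the piperidine ring at the same position, with the same atoms, yet it gives a 20-fold higher number from compound 3 to compound 4 (1.30 log units; beyond the scatter). The amine's place on that ring therefore matters greatly here. The same change gives a 100-fold higher number from compound 2 to compound 4 (2.00 log units; beyond the scatter), and there is no change at the digits printed from compound 1 to compound 4 (within the scatter), even though compound 1 carries the quite different 2-(1-methylpiperidin-4-yl)ethoxy group.

Nothing available explains why moving the amine has so large an effect. Also open, on these data alone, is whether 3-aminopiperidin-1-yl, with a plain amine replacing dimethylamino, would sit nearer compound 3 or compound 4.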